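A Benzylamine to Benzylamide Step in One Series

The compounds below may be only part of what the source reports. "The series", "measured", "known", "first", "only" and "open" are said of these compounds alone.

Measured so far:
Compound 1, `C=C1CC[C@@H]2[C@](C)(CNCc3ccccc3)[C@H](O)CC[C@@]2(C)[C@@H]1/C=C/C1=CCOC1=O`: 960 nM
Compound 2, `C=C1CC[C@@H]2[C@](C)(CNCc3ccc(C)cc3)[C@H](O)CC[C@@]2(C)[C@@H]1/C=C/C1=CCOC1=O`: 740 nM
Compound 3, `C=C1CC[C@@H]2[C@](C)(CNCc3ccc(OC)cc3)[C@H](O)CC[C@@]2(C)[C@@H]1/C=C/C1=CCOC1=O`: 750 nM

Of the compounds shown here, three have been tested in a functional assay on BMMC cells (Mus musculus, strain C57BL/6) for inhibition, with stated times of 5 days and 48 h; on this read-out higher numbers stand for weaker inhibition and lower numbers for stronger inhibition. Compound 2 holds the lowest of the three numbers, but its separation from the others, a 1.3-fold lower number from compound 1 to compound 2 (0.11 log units; within the scatter) and a 1.0-fold higher number from compound 2 to compound 3 (0.01 log units; within the scatter), lies within the scatter, so no order among the three can be claimed. Compound 4, `C=C1CC[C@H]2[C@@](C)(CC[C@@H](O)[C@@]2(C)C(=O)NCc2ccc(Br)cc2)[C@@H]1/C=C/C1=CCOC1=O`, has not yet been measured. It differs from compound 2 by (4-bromobenzyl)carbamoyl in place of ((4-methylbenzyl)amino)methyl on a saturated ring carbon. The measured steps of a 1.3-fold lower number from compound 1 to compound 2 (0.11 log units; within the scatter), a 1.3-fold lower number from compound 1 to compound 3 (0.11 log units; within the scatter) and a 1.0-fold higher number from compound 2 to compound 3 (0.01 log units; within the scatter) all concern only the substituent on the aromatic ring and all stayed within the scatter; none of them tests the exchange of the aminomethyl linker for a carbamoyl, which is the larger part of the present change. Within the data shown here, the data therefore give no direction for this step, and the uncertainty is wide. Compound 4 is expected to give about 1500 nM in this assay, somewhere between 300 nM and 8000 nM, which corresponds to an expected 2.0-fold higher number from compound 2 to compound 4 (0.31 log units; beyond the scatter).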

Compound 4, half-maximal inhibitory concentration: 3450 nM
Compound 4: middle estimate off by 2.3-fold (0.36 log units), on the low side, and the stated range covers the measured number.
By their numbers in this assay, from the lowest: compounds 2, 3 and 1 (each within the scatter of the next); then compound 4.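

Among these compounds, only the exchange of an aminomethyl-linked benzyl group for (4-bromobenzyl)carbamoyl on this saturated ring carbon moves the number in this assay beyond the scatter, with all three steps pointing towards weaker inhibition (a 4.7-fold higher number from compound 2 to compound 4 (0.67 log units; beyond the scatter)) and (a 4.6-fold higher number from compound 3 to compound 4 (0.66 log units; beyond the scatter)) and (a 3.6-fold higher number from compound 1 to compound 4 (0.56 log units; beyond the scatter)). The steps are of similar modest size whichever of the three benzylamines is the starting point, so this position responds to the change in a way the aromatic substituent steps among compounds 1, 2 and 3 did not show. No measurement here explains the shift.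

The linker and the ring substituent change together, so their shares cannot be separated. From the compounds shown here alone, a ((4-bromobenzyl)amino)methyl group or an unsubstituted benzylcarbamoyl group would divide the step, and a carboxylic acid at this carbon remains untested here.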